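The compounds below may be only part of what the source reports. "The series", "measured", "known", "first", "only" and "open" are said of these compounds alone.

Compound 1 `O=c1n(Cc2nc(-c3nccs3)cn2CCCCO)c2cnccc2n1C1CC1` belongs to a small set of compounds examined in an ADME assay on microsomes from liver (Homo sapiens) for metabolic stability; on this read-out higher numbers stand for fast clearance and lower numbers for slow clearance. For compound 1 this assay reports only a limit, < 8 mL.min-1.g-1, and not a measured number; this is the limit of < 8 mL.min-1.g-1 in this assay, at which 1 of the 3 values shown sits. The two compounds with measured numbers are compound 2 `COC(=O)N1CCC(n2c(=O)n(Cc3nc4ccccc4n3CCCCO)c3ccccc32)CC1`, which in this assay gives 44 mL.min-1.g-1, and compound 3 `CC(C)n1nc(Cn2nc3ccccc3c2OCCCO)c2ccccc21`, which in this assay gives 246 mL.min-1.g-1. Compound 4 `Cn1ccnc1-c1cn(CCCCO)c(Cn2c(=O)n(C3CC3)c3ccncc32)n1` has not yet been measured in this assay. It differs from compound 1 in one place: 1-methyl-1H-imidazol-2-yl in place of 1,3-thiazol-2-yl on an aromatic carbon. Among the measured compounds shown here, no step between measured compounds resembles this change, so its size cannot be read from the data; the expectation is for no change beyond the scatter. Compound 4 is therefore expected to give about 8 mL.min-1.g-1, with a range from 4 mL.min-1.g-1 to 20 mL.min-1.g-1. That estimate means an expected step from compound 1 to compound 4 of a number no lower from compound 1 to compound 4 (the limit leaves the size open).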

Compound 4, intrinsic clearance in microsomes: < 8 mL.min-1.g-1
Compound 4: only a limit was reported; the forecaster's own chance of this, stated with the estimate: 50%; the middle value sits exactly at the limit.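

In this assay, among the compounds shown here, compound 1 and compound 4 each give only a limit, not a number, so no step between them can be read: the limit of < 8 mL.min-1.g-1 in this assay, at which 2 of the 4 values shown sit. The compounds shown leave open whether 1-methyl-1H-imidazol-2-yl in place of 1,3-thiazol-2-yl changes clearance at all.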